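Swapping the aryl on the ring nitrogen for methyl

The source may report more compounds than this note shows. Statements on the series, on what has been measured and on what is new or still open speak of the compounds shown alone.

Measured compounds:
compound 1 `CCOC(=O)C1=C(C)N/C(=C/c2cc(C)n(-c3cccc(C(F)(F)F)c3)c2C)C1=O` — 100000 nM
compound 2 `CCOC(=O)C1=C(C)N/C(=C/c2cc(C)n(-c3ccc(F)cc3F)c2C)C1=O` — 14000 nM
compound 3 `CCOC(=O)C1=C(C)N/C(=C/c2cc(C)n(-c3ccncc3)c2C)C1=O` — 100000 nM

For the measured compounds named here, in an ADME assay on L6 cells (Rattus norvegicus) for cytotoxicity, read by resazurin assay, with a stated time of 72 h (a higher number here means that more compound is needed for the effect, a lower number that less compound is needed), compound 1 gives 100000 nM and stands level with compound 3, together the highest of the three numbers; the only step beyond the scatter is a 7.1-fold lower number from compound 1 to compound 2 (0.85 log units; beyond the scatter). Compound 4 `CCOC(=O)C1=C(C)N/C(=C/c2cc(C)n(C)c2C)C1=O` differs from compound 1 by methyl in place of 3-(trifluoromethyl)phenyl on an aromatic nitrogen. Going by the values given here, no measured step exchanges an aromatic ring for a methyl group at this position. Among the compounds with values here, the steps that bear on it are no change at the digits printed from compound 1 to compound 3 (within the scatter) and a 7.1-fold lower number from compound 1 to compound 2 (0.85 log units; beyond the scatter), showing the number either unchanged or modestly lower. Compound 4 is therefore expected near compound 1, with a step of a 1.3-fold lower number from compound 1 to compound 4 (0.10 log units; within the scatter) at most. The estimate for compound 4 is 80000 nM, between 20000 nM and 100000 nM.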

Compound 4, half-maximal effective concentration: 310000 nM
Compound 4: the middle estimate sits 3.9-fold (0.59 log units) below what was measured; measured number outside the range, above it.
By their numbers in this assay, from the lowest: compound 2; then compounds 1 and 3 (each within the scatter of the next); then compound 4.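

In this assay, methyl on the aromatic nitrogen gives a higher number than each aromatic ring tried there (a 3.1-fold higher number from compound 1 to compound 4 (0.49 log units; beyond the scatter)) (a 3.1-fold higher number from compound 3 to compound 4 (0.49 log units; beyond the scatter)) (a 22-fold higher number from compound 2 to compound 4 (1.35 log units; beyond the scatter)). The position therefore needs no aromatic ring for a high number, and the step is largest from the 2,4-difluorophenyl compound. No measurement shown here accounts for this. From the compounds shown here alone, it remains open whether a longer chain, such as ethyl or propyl, would stay near methyl. Going by these compounds, it is also open whether a single fluorine on the phenyl ring would give a number nearer that of compound 2 or compound 1.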